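The source may report more compounds than this note shows. Statements on the series, on what has been measured and on what is new or still open speak of the compounds shown alone.

Measured compounds in an assay on CHO cells for displacement of a labelled ligand from adenosine receptor A1 (Homo sapiens), read by scintillation counting, tested at 10 uM; on this read-out lower numbers stand for less inhibition and higher numbers for more inhibition at the one concentration tested (going by the name of the read-out):
compound 1 `CC(C)(C)Cc1csc(N)c1C(=O)c1ccc(Cl)cc1`: 1%
compound 2 `CC(C)(C)Cc1c(-c2cccnc2)sc(N)c1C(=O)c1ccc(Cl)cc1`: 1%
compound 3 `CC(C)(C)Cc1c(-c2ccc(F)cc2F)sc(N)c1C(=O)c1ccc(Cl)cc1`: 1%

In this assay compound 1 stands level with compounds 2 and 3; the step of no change at the digits printed from compound 1 to compound 2 (within the scatter) and the step of no change at the digits printed from compound 1 to compound 3 (within the scatter) are both within the scatter, as is the step of no change at the digits printed from compound 2 to compound 3 (within the scatter) between the two aryl-bearing compounds. Going by the values given here, the series so far shows no movement at all.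

Compound 4 `Cc1ccc(-c2sc(N)c(C(=O)c3ccc(Cl)cc3)c2CC(C)(C)C)cc1` is the next member. It differs from compound 1 by 4-methylphenyl in place of hydrogen on an aromatic carbon. The two measured steps that bear on this change are those from compound 1 to compound 2 and from compound 1 to compound 3, where an aromatic ring replaces the same hydrogen on the shared core; neither moved the read-out beyond the scatter. A 4-methylphenyl ring at this position is therefore expected to behave the same way, with the step of no change at the digits printed from compound 1 to compound 4 (within the scatter) expected to stay within the scatter. Compound 4 is estimated to give 1% in this assay, with a range from 0% to 10%.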

Compound 4, a percentage reported as inhibition, at one concentration (the size of the read-out at that concentration, not a potency): 1%
Compound 4: the middle estimate sits on the measured number at the digits printed; the measured number falls inside the stated range.
By their numbers in this assay, from the lowest: compounds 1, 2, 3 and 4 (each within the scatter of the next).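

In this assay, a carbon-only aromatic ring carrying a methyl group now joins the two earlier aryl groups on the aromatic carbon next to the ring sulfur, and the step of no change at the digits printed from compound 1 to compound 4 (within the scatter) stays as flat as theirs. The comparisons among the aryl groups are equally flat, with no change at the digits printed from compound 3 to compound 4 (within the scatter) and no change at the digits printed from compound 2 to compound 4 (within the scatter), so 4-methylphenyl, 2,4-difluorophenyl and pyridin-3-yl cannot be told apart at this position in this read-out. Nothing available bears on why the read-out stays flat here.

Going by these compounds, with all four compounds level, it remains open whether any change at this position can move the read-out, for instance a carboxylic acid or an amine on the added ring. Also open, on these data alone, is whether a longer chain in place of the neopentyl group, or a replacement of the (4-chlorophenyl)carbonyl group, would do so.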